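The source may report more compounds than this note shows. Statements on the series, on what has been measured and on what is new or still open speak of the compounds shown alone.

Four nucleoside analogues that share a sugar-bearing core are compared here for how strongly they slow the growth of a human cell line, measured in a functional assay on HL-60 cells (Homo sapiens) for antiproliferative activity, read by XTT assay, with a stated time of 72 h; a lower number here means a stronger inhibitor, a higher number a weaker inhibitor. Compound 1 `Cc1ncnc2c1c(I)cn2[C@@H]1O[C@H](CO)[C@@H](O)[C@H]1O` carries an iodine on its core and in this assay gives 2650 nM. Compound 2 `Cc1ncnc2c1c(-c1ccoc1)cn2[C@@H]1O[C@H](CO)[C@@H](O)[C@H]1O` differs from it in one place: furan-3-yl in place of iodo on an aromatic carbon. For compound 2 this assay reports only a limit, > 15000 nM. The step is therefore an at least 5.6-fold higher number from compound 1 to compound 2 (0.75 log units; beyond the scatter), and its true size stays hidden because of the limit of > 15000 nM in this assay, at which 1 of the 3 values shown sits.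

Compound 3 `Cc1nc(N)c2c(I)cn([C@@H]3O[C@H](CO)[C@@H](O)[C@H]3O)c2n1` has a different core from compound 1; the difference between the two cores is not broken down here. In this assay compound 3 gives 2050 nM, a value that sits within the usual scatter of compound 1, so the two cannot be ranked against each other.

Compound 4 `Cc1nc(N)c2c(-c3ccoc3)cn([C@@H]3O[C@H](CO)[C@@H](O)[C@H]3O)c2n1` is built from compound 3 by the same change seen before: furan-3-yl in place of iodo on an aromatic carbon. The surroundings of the place are the same in both pairs. Since compound 3 gives 2050 nM and the same change gave an at least 5.6-fold higher number from compound 1 to compound 2 (0.75 log units; beyond the scatter), compound 4 is expected to lose potency by about a 6.8-fold higher number from compound 3 to compound 4 (0.83 log units; beyond the scatter). The estimate for compound 4 in this assay is 14000 nM, with a range from 6000 nM to 40000 nM, and there is a fair chance that only a limit is reported for it.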

Compound 4, half-maximal inhibitory concentration: > 20000 nM
Compound 4 ended at the assay's limit; the forecaster's own chance of this, stated with the estimate: 55%; at least 1.4-fold (0.15 log units) between middle value and limit.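

In this assay compound 4 gives > 20000 nM and this is a limit of the assay, not a number. Putting furan-3-yl in place of iodo on this aromatic carbon thus gives an at least 9.7-fold higher number from compound 3 to compound 4 (0.98 log units; beyond the scatter) and so, on both cores shown, the change moves the same way, towards a weaker inhibitor, by a step beyond the scatter. In this pair of cores the loss of activity carries over from one to the other, but neither step has a known true size, and nothing shows whether the loss is larger on one core than on the other: the same change on two cores in this assay, an at least 5.6-fold higher number (0.75 log units; beyond the scatter) from compound 1 to compound 2 and an at least 9.7-fold higher number (0.98 log units; beyond the scatter) from compound 3 to compound 4; the limit leaves it open whether they differ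

The compounds shown hold only iodo or furan-3-yl at this place, so they cannot separate what is special to the furan ring from what any other replacement for iodo would do. From the compounds shown here alone, it stays open whether a small group such as methyl, an amine, a nitrile, a phenyl ring or a longer chain on the same carbon would keep the activity of the two iodo compounds or lose it as furan-3-yl does, and whether the same holds on any further core.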